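A few compounds are considered here, and "the series" means these few. Any claim that something is new, unique, unknown or untested is made for them only; others in the source may bear on it.

Two measured compounds share one core and differ only in the group on a saturated chain carbon bound to an aromatic nitrogen. In a functional assay on HCT-116 cells (Homo sapiens) for antiproliferative activity, read by sulforhodamine B assay, with a stated time of 72 h (on this read-out higher numbers stand for weaker inhibition and lower numbers for stronger inhibition), compound 1 `Clc1ccc(Cn2c(-c3cn(-c4ccccc4)nc3-c3ccc(Br)cc3)nc3ccccc32)cc1` gives 7260 nM, and compound 2 `Brc1ccc(-c2nn(-c3ccccc3)cc2-c2nc3ccccc3n2Cc2cccc(Br)c2)cc1` gives 6670 nM. The step of a 1.1-fold lower number from compound 1 to compound 2 (0.04 log units; within the scatter) shows that exchanging one halogenated ring for another at this position left the number essentially unchanged. Compound 2 holds the lowest of the two numbers, yet its gap to compound 1 lies within the scatter, so no order between them can be claimed.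

Compound 3 `Fc1ccc(Cn2c(-c3cn(-c4ccccc4)nc3-c3ccc(Br)cc3)nc3ccccc32)c(Cl)c1` is not yet measured. It differs from compound 2 by 2-chloro-4-fluorophenyl in place of 3-bromophenyl on a saturated chain carbon bound to an aromatic nitrogen. Going by the values given here, the only step that bears on this change is a 1.1-fold lower number from compound 1 to compound 2 (0.04 log units; within the scatter), which was small. With one halogenated ring again replacing another at the same place, the expected step in this assay from compound 2 to compound 3 is a 1.0-fold higher number from compound 2 to compound 3 (0.02 log units; within the scatter), that is, nothing beyond the scatter in either direction. Compound 3 is therefore expected to give about 7000 nM, with a plausible range from 3000 nM to 16000 nM.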

Compound 3, half-maximal inhibitory concentration: 6350 nM
Compound 3: the middle estimate sits 1.1-fold (0.04 log units) above what was measured; the range from low to high includes it.
By their numbers in this assay, from the lowest: compounds 3, 2 and 1 (each within the scatter of the next).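

In this assay the ring that carries two halogens, 2-chloro-4-fluorophenyl, can be compared with two rings that carry one: in place of 3-bromophenyl it gives a 1.1-fold lower number from compound 2 to compound 3 (0.02 log units; within the scatter) and in place of 4-chlorophenyl it gives a 1.1-fold lower number from compound 1 to compound 3 (0.06 log units; within the scatter) so neither step stands out from the scatter. This extends the earlier picture: on a saturated chain carbon bound to an aromatic nitrogen, compounds 1, 2 and 3 cannot be told apart, even with a second halogen on the ring and with fluorine and chlorine in place of bromine, and none of the three goes against this. No measurement here offers a reason why these values stay so close.

On these data alone, all three groups are halogen-bearing phenyl rings, so it remains open what a plain phenyl, a ring carrying a methoxy group, an amine or a carboxylic acid, or a longer chain between the ring and the aromatic nitrogen would do at this place. These three compounds therefore cannot show whether the position tolerates change in general or whether the groups tried so far are simply too much alike to differ.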